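This account rests on a few compounds, and the source may have more. Where it says the series, first, only, none or still open, it means among the compounds named here.

Compound 1 `COc1ccc(-c2nc3cc(F)ccc3s2)cc1`: 24600 nM
Compound 2 `COc1ccc(-c2nc3cc(F)ccc3s2)cc1C`: 18600 nM
Compound 3 `Oc1ccc(-c2nc3cc(F)ccc3s2)cc1O`: 13000 nM

In a functional assay on KM12 cells (Homo sapiens) for antiproliferative activity (a higher number here means a weaker inhibitor of growth, a lower number a stronger inhibitor of growth), compound 1 stands level with compound 2 and compound 3, since the gaps among all three lie within the usual scatter. Compound 4 `COc1ccc(-c2nc3cc(F)ccc3s2)cc1OC` is still unmeasured. The change methoxy in place of hydrogen on an aromatic carbon puts methoxy in place of hydrogen on an aromatic carbon of compound 1. For the measured compounds named here, the one measured single-place step, methyl in place of hydrogen on an aromatic carbon, is a 1.3-fold lower number from compound 1 to compound 2 (0.12 log units; within the scatter) and gives no sign of a real shift. One small step is a thin base, so the expected result is no change beyond the scatter, in either direction, with a wide range. Going by the values given here, the expected size is a 1.5-fold lower number from compound 1 to compound 4 (0.19 log units; within the scatter) and thus no real step. For compound 4 the estimated value is 16000 nM with an expected range from 5000 nM to 40000 nM as its upper end.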

Compound 4, concentration for 50% growth inhibition: 290 nM
Estimate against measurement, compound 4: 55-fold (1.74 log units) above; measured number below the stated range.
By their numbers in this assay, from the lowest: compound 4; then compounds 3, 2 and 1 (each within the scatter of the next).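

In this assay, this position proves far more sensitive than the methyl step suggested: methoxy on the aromatic carbon ortho to a methoxy group gives an 85-fold lower number from compound 1 to compound 4 (1.93 log units; beyond the scatter). Replacing methyl with methoxy at that same place gives a 64-fold lower number from compound 2 to compound 4 (1.81 log units; beyond the scatter), so simply filling the position is not enough and the identity of the group matters. No measurement shown here explains why this change has such a large effect. Still open, going by these compounds, is how the number would respond to an ethoxy group, a longer chain or an amine at this place.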